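The source may hold more compounds than are shown below. What is called first, only, known or untested is meant among the compounds shown, and "the series" means these compounds.

Compound 1 `Nc1cc(=O)[nH]c(=O)n1[C@@H]1O[C@H](CO)[C@@H](O)[C@H]1O` is the starting point. In a functional assay on LOX cells (Homo sapiens) for antiproliferative activity, read by WST assay, with a stated time of 3 days (a lower number here means a stronger inhibitor, a higher number a weaker inhibitor), compound 1 gives > 50000 nM, which is a limit of the assay rather than a number. Compound 2 `COC(=O)c1cc(=O)[nH]c(=O)n1[C@@H]1O[C@H](CO)[C@@H](O)[C@H]1O` carries methoxycarbonyl in place of amino on an aromatic carbon; in this assay compound 2 gives > 50000 nM, again a limit. Compound 3 `O=c1cc(NO)n([C@@H]2O[C@H](CO)[C@@H](O)[C@H]2O)c(=O)[nH]1` carries hydroxy in place of hydrogen on a nitrogen on an aromatic ring; in this assay compound 3 gives > 50000 nM, also a limit. The measured steps a step that the two limits leave unreadable from compound 1 to compound 2, a step that the two limits leave unreadable from compound 1 to compound 3 and a step that the two limits leave unreadable from compound 2 to compound 3 cannot be sized because the limit of > 50000 nM in this assay, at which 3 of the 3 values shown sit, holds for every value shown. Compound 4 `Nc1c(F)c(=O)[nH]c(=O)n1[C@@H]1O[C@H](CO)[C@@H](O)[C@H]1O` differs from compound 1 by fluoro in place of hydrogen on an aromatic carbon. Among the compounds with values here, no measured step on this core can be read, so there is no basis for expecting a step in this assay in either direction beyond the scatter. Thus the expected step is a number no higher from compound 1 to compound 4 (the limit leaves the size open). Compound 4 is expected to give about 50000 nM in this assay, between 15000 nM and 150000 nM, most likely reported as a limit.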

Compound 4, half-maximal inhibitory concentration: 3400 nM
For compound 4 the middle estimate is 15-fold (1.17 log units) above the measured one, and the stated range ends above it.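

In this assay, within the data shown here, fluoro in place of hydrogen on an aromatic carbon, ortho to an amino group, gives an at least 14-fold lower number from compound 1 to compound 4 (1.16 log units; beyond the scatter) and is the first step on this core that can be read, whereas the steps among compound 1, compound 2 and compound 3 cannot be read. This shows that the carbon ortho to the amino group is a position where a single fluorine atom changes the read-out beyond the scatter. Compound 4 is the only compound shown that gives a number rather than a limit: the limit of > 50000 nM in this assay, at which 3 of the 4 values shown sit.

The compounds shown leave open whether chloro, methyl or hydroxy on this carbon would give a similar step. They also leave open whether fluoro would have the same effect with methoxycarbonyl or hydroxyamino in place of the amino group.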